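The compounds below may be only part of what the source reports. "The series", "measured", "known", "first", "only" and "open" are said of these compounds alone.

Compound 2 `CCOC(=O)C1=C(C)N/C(=C/c2cc(C)n(-c3ccncc3)c2C)C1=O` gives 50 ug/mL in a physicochemical assay for solubility, read by nephelometry, in phosphate buffer, measured as kinetic solubility, at pH 6.5 (on this read-out lower numbers stand for lower solubility and higher numbers for higher solubility), the higher of the two numbers seen so far. Compound 1 `CCOC(=O)C1=C(C)N/C(=C/c2cc(C)n(-c3ccc(SC)cc3)c2C)C1=O` gives 1.6 ug/mL in this assay, and the step of a 31-fold higher number from compound 1 to compound 2 (1.49 log units; beyond the scatter) was large. Compound 3 `CCOC(=O)C1=C(C)N/C(=C/c2cc(C)n(-c3cccnc3)c2C)C1=O` has not yet been measured; it differs from compound 2 by pyridin-3-yl in place of pyridin-4-yl on an aromatic nitrogen. Among the compounds with values here, the one measured step swapped a different group altogether and bears on this change only loosely; no measured step compares the two pyridinyl groups directly. The step of a 1.3-fold lower number from compound 2 to compound 3 (0.10 log units; within the scatter) is therefore expected to stay within the usual scatter. Compound 3 is estimated at 40 ug/mL, in a range from 15 ug/mL to 120 ug/mL.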

Compound 3, solubility: 25 ug/mL
Beside the measured number, compound 3's estimate is 1.6-fold (0.20 log units) above it; the range from low to high includes it.
By their numbers in this assay, from the lowest: compound 1; then compounds 3 and 2 (each within the scatter of the next).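

In this assay, the swap shows a 2.0-fold lower number from compound 2 to compound 3 (0.30 log units; within the scatter), so the two pyridinyl groups cannot be told apart on this aromatic nitrogen. The step of a 16-fold higher number from compound 1 to compound 3 (1.19 log units; beyond the scatter) shows that the large rise from the 4-(methylsulfanyl)phenyl compound is not tied to pyridin-4-yl alone, since it appears with both pyridinyl groups. No outside measurement is available to explain these results.

Still open, as far as these compounds go, is whether pyridin-2-yl or plain phenyl would give a similar number on this nitrogen. Also open, from the compounds shown here alone, is how a phenyl ring carrying an amine or a carboxylic acid would compare.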